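A few compounds are considered here, and "the series" means these few. Any claim that something is new, unique, unknown or untested is made for them only; others in the source may bear on it.

Compound 1 `COc1cc(C(=O)/C=C\Nc2ccc(-c3nc4cc(OC)c(OC)c(OC)c4s3)cc2)c(Br)c(OC)c1OC`: 23200 nM
Compound 2 `COc1cc(C(=O)/C=C\Nc2ccc(-c3nc4cc(OC)c(OC)c(OC)c4s3)cc2C)c(Br)c(OC)c1OC`: 24300 nM
Compound 3 `COc1cc(OC)c2sc(-c3ccc(N/C=C\C(=O)c4cc(OC)c(OC)c(OC)c4Br)cc3)nc2c1`: not yet measured

Within the data shown here, in a functional assay on MIA PaCa-2 cells (Homo sapiens) for antiproliferative activity, read by sulforhodamine B assay, with a stated time of 48 h (a lower number here means a stronger inhibitor, a higher number a weaker inhibitor), compound 1 stands within the scatter of compound 2, the only other compound measured. Compound 3 departs from compound 1 by one change: hydrogen in place of methoxy on an aromatic carbon. In words, this is hydrogen in place of methoxy on an aromatic carbon. Among the measured compounds shown here, the sole measured step, a 1.0-fold higher number from compound 1 to compound 2 (0.02 log units; within the scatter), is a different change, methyl in place of hydrogen, so it bears only weakly on this one. No step beyond the scatter is therefore expected in this assay, though with wide uncertainty. The expected step is a 1.2-fold lower number from compound 1 to compound 3 (0.06 log units; within the scatter). For compound 3 the estimated value is 20000 nM, with an expected range from 7000 nM to 50000 nM.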

Compound 3, half-maximal inhibitory concentration: 19000 nM
The estimate for compound 3 lay 1.1-fold (0.02 log units) above the measured number; low and high end bracket the measured number.
By their numbers in this assay, from the lowest: compounds 3, 1 and 2 (each within the scatter of the next).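

In this assay the methoxy ortho to two methoxy groups, on the ring of the fused system of two rings, gives way to hydrogen with no step beyond the scatter (a 1.2-fold lower number from compound 1 to compound 3 (0.09 log units; within the scatter)). Among these compounds, compound 2 had tested only a methyl on another ring, so this is the first sign that the fused part tolerates a change at this level of activity. Nothing measured here accounts for this result. On these data alone, whether an amine, a carboxylic acid or a longer chain on this carbon would leave the number in the same range stays open. So does the effect of replacing the two remaining methoxy groups on that ring with hydrogen.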